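The source may report more compounds than this note shows. Statements on the series, on what has been measured and on what is new or still open speak of the compounds shown alone.

Compounds measured in a functional assay on the whole organism for inhibition, with Rattus norvegicus as the target, read by paw edema; a higher number here means that more compound is needed for the effect, a lower number that less compound is needed:
- compound 1, `O=C(O)c1cc(-c2csnn2)ccc1O`: > 200 mg/kg
- compound 2, `O=C(O)c1cc(C2N=NN=N2)ccc1O`: 110 mg/kg
- compound 3, `O=C(O)c1cc(-c2ncc[nH]2)ccc1O`: 200 mg/kg

The value of compound 1 is a limit of this assay, not a number; the evidence there is the limit of > 200 mg/kg in this assay, at which 1 of the 3 values shown sits. Among the two numbers shown, compound 3 has the higher one, but the nearest value, that of compound 2, differs by a 1.8-fold higher number from compound 2 to compound 3 (0.26 log units; within the scatter), so no order between compound 2 and compound 3 can be read. From compound 1 to compound 3 the step is a number no higher from compound 1 to compound 3 (the limit leaves the size open), and from compound 1 to compound 2 it is an at least 1.8-fold lower number from compound 1 to compound 2 (0.25 log units; that floor lies within the scatter).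

Compound 4, `O=C(O)c1cc(-c2cccs2)ccc1O`, is not yet measured. Its change from compound 3 is thiophen-2-yl in place of 1H-imidazol-2-yl on an aromatic carbon. Every measured step in this set replaces one five-membered ring with another at the same aromatic carbon, and none of them moved the number beyond the scatter or out of the limit. On that basis the step to compound 4 is expected to stay within the scatter as well: the estimated step is no change at the digits printed from compound 3 to compound 4 (within the scatter). For compound 4 the expected value in this assay is 200 mg/kg, with a range from 90 mg/kg to 400 mg/kg, and a real chance that only a limit is returned.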

Compound 4, dose for half-maximal effect: 60 mg/kg
For compound 4 the middle estimate is 3.3-fold (0.52 log units) above the measured one, and the stated range ends above it.
By their numbers in this assay, from the lowest: compounds 4, 2 and 3 (each within the scatter of the next, the first and the last beyond it).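

At this position, on an aromatic carbon meta to a carboxy group and para to a hydroxy group, exchanging one five-membered aromatic ring for another can move the number in this assay: with thiophen-2-yl in place of 1H-imidazol-2-yl the result is a 3.3-fold lower number from compound 3 to compound 4 (0.52 log units; beyond the scatter), a size that no step among the earlier compounds had shown. With thiophen-2-yl in place of 1,2,3-thiadiazol-4-yl the result is an at least 3.3-fold lower number from compound 1 to compound 4 (0.52 log units; beyond the scatter), whereas the exchange for the non-aromatic ring of 1 carbon and 4 nitrogen gives a 1.8-fold lower number from compound 2 to compound 4 (0.26 log units; within the scatter), so no order can be read for that pair. The value of compound 1 is a limit of this assay, not a number: the limit of > 200 mg/kg in this assay, at which 1 of the 4 values shown sits.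

Which ring atoms carry the step stays open, as thiophen-2-yl and 1,2,3-thiadiazol-4-yl both hold sulfur and still differ beyond the scatter. All the groups shown at this position are five-membered rings, so the effect of a phenyl ring, a thiophen-3-yl group or a methyl group on the thiophene is also open.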